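A few compounds are considered here, and "the series" means these few. Any claim that something is new, unique, unknown or untested is made for them only; others in the source may bear on it.

Compound 1 `Cn1c(-c2ccc(NC(=O)CCl)cc2)nc(-c2ccccc2)c1-c1ccccc1`: 14.4%
Compound 2 `Cn1c(-c2ccc(NC(=O)CSc3nc4ccccc4o3)cc2)nc(-c2ccccc2)c1-c1ccccc1`: 41%
Compound 3 `Cn1c(-c2ccc(NC(=O)CSc3nc4ccccc4s3)cc2)nc(-c2ccccc2)c1-c1ccccc1`: 15.3%

All three share one core and differ only in the group on the saturated chain carbon bound to a carbonyl carbon. In a functional assay on HT-29 cells (Homo sapiens) for cytotoxicity, read by MTT assay, with a stated time of 24 h, tested at 1.6 ug/mL (a higher number here means a stronger effect of the compound at the concentration tested, a lower number a weaker effect), compound 3 stands second highest of the three numbers, yet only compound 2 is separated from it beyond the scatter: a number 0.9 percentage points higher from compound 1 to compound 3 (within the scatter), while a number 25.7 percentage points lower from compound 2 to compound 3 (beyond the scatter).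

Compound 4 `Cn1nnnc1SCC(=O)Nc1ccc(-c2nc(-c3ccccc3)c(-c3ccccc3)n2C)cc1` brings a change without a direct precedent: 1-methyl-1H-tetrazol-5-yl in place of 1,3-benzothiazol-2-yl on a sulfur. Among the compounds with values here, the only step that swaps the ring on the sulfur is modest, and swapping a ring for a chloro left the number unchanged, so no step beyond the scatter is expected: a number 2.7 percentage points higher from compound 3 to compound 4 (within the scatter). Compound 4 is therefore estimated at 18%, between 5% and 35%.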

Compound 4, a percentage reported as activity, at one concentration (the size of the read-out at that concentration, not a potency): 49.8%
Estimate against measurement, compound 4: 31.8 percentage points below; the measured number lies above the stated range.
By their numbers in this assay, from the lowest: compounds 1 and 3 (each within the scatter of the next); then compounds 2 and 4 (each within the scatter of the next).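

In this assay, the ring on the sulfur can matter a great deal: a number 34.5 percentage points higher from compound 3 to compound 4 (beyond the scatter). The earlier compounds shown here showed one such ring giving no change from chloro, whereas here a number 35.4 percentage points higher from compound 1 to compound 4 (beyond the scatter), and compound 3 remains the exception to any gain from a sulfur-linked ring. The single-ring tetrazole also matches the benzoxazole, a number 8.8 percentage points higher from compound 2 to compound 4 (within the scatter), so the benzothiazole stands apart from both. No available evidence explains these differences. On these data alone, how a morpholine amine or a carboxylic acid would behave on the saturated chain carbon bound to a carbonyl carbon remains open.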